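The compounds below may be only part of what the source reports. "The series", "measured", "known", "first", "only" and "open" are said of these compounds alone.

Compound 1 `O=C(O)[C@@H]1CCCN1C(=O)CN(c1nc(Cl)nc2[nH]cnc12)C1CC1`: 23.6%
Compound 2 `N=C(N)NCCC[C@H](NC(=O)CN(c1nc(Cl)nc2[nH]cnc12)C1CC1)C(=O)O`: 17%

In a functional assay on the whole organism (Tail, strain ICR) with Mus musculus as the target, in the tail flick test, with a stated time of 120 min, at a dose of 25 umol/kg by the oral route (on this read-out lower numbers stand for a weaker effect and higher numbers for a stronger effect at the one dose given), compound 1 gives 23.6% and compound 2 gives 17%. The value of compound 2 differs from that of compound 1 by less than the usual scatter, so the two cannot be told apart on these numbers. Compound 3 `O=C(O)CNC(=O)CN(c1nc(Cl)nc2[nH]cnc12)C1CC1` differs from compound 2 by a hydrogen atom in place of a group of 7 heavy atoms (4 carbon, 3 nitrogen; no ring), on a saturated chain carbon bound to an amide-type nitrogen and a carbonyl carbon. Among the compounds with values here, no step between measured compounds is known, so the effect of this change is uncertain; with both measured values close together, compound 3 is expected to show a step of a number 3 percentage points higher from compound 2 to compound 3 (within the scatter), not beyond the scatter. Compound 3 is expected to give 20%, ranging from 8% to 35%.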

Compound 3, a percentage reported as activity, at one dose (the size of the read-out at that dose, not a potency): 19.8%
Beside the measured number, compound 3's estimate is 0.2 percentage points above it; the measured number falls inside the stated range.
By their numbers in this assay, from the lowest: compounds 2, 3 and 1 (each within the scatter of the next).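

In this assay, a hydrogen atom in place of the group of 7 heavy atoms on the saturated chain carbon gives a number 2.8 percentage points higher from compound 2 to compound 3 (within the scatter). Likewise, (carboxymethyl)amino in place of 2-carboxypyrrolidin-1-yl on the carbonyl carbon gives a number 3.8 percentage points lower from compound 1 to compound 3 (within the scatter). Neither the group of 7 heavy atoms nor the pyrrolidine ring is therefore needed for a read-out in this range, although no measured evidence explains why. From the compounds shown here alone, it remains open whether a methyl group or a longer chain on that carbon, or an amine in place of the carboxylic acid, would give a number beyond the scatter.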